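Swapping the halogenated phenyl on the sulfonyl of compound 1

The source may hold more compounds than are shown below. What is called first, only, known or untested is meant among the compounds shown, and "the series" means these compounds.

Measured so far:
- compound 1 `Cn1c(=O)c(S(=O)(=O)c2ccc(Cl)cc2Cl)cc2cnc(Nc3ccc4[nH]ccc4c3)nc21`: 1000 nM
- compound 2 `Cn1c(=O)c(S(=O)(=O)c2ccccc2)cc2cnc(Nc3cnc4[nH]ccc4c3)nc21`: 5000 nM
- compound 3 `Cn1c(=O)c(S(=O)(=O)c2ccc(OC(=O)CCCCC3SCC4NC(=O)NC43)cc2)cc2cnc(Nc3ccc4[nH]ccc4c3)nc21`: 600 nM

All three share one core and were tested in a functional assay on K562 cells (Homo sapiens) for inhibition, read by trypan blue exclusion, with a stated time of 72 h; a lower number here means a stronger inhibitor, a higher number a weaker inhibitor. Compound 1 gives 1000 nM, the second highest of the three numbers. Compound 3 sits nearest to it, within the usual scatter, so the two cannot be told apart. For the measured compounds named here, compound 2 lies furthest from compound 1, beyond the scatter, with the higher number of the two, but it differs from compound 1 in more than one place, so no single step can be drawn from its value.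

The unmeasured compound 4 `Cn1c(=O)c(S(=O)(=O)c2ccc(Br)cc2)cc2cnc(Nc3ccc4[nH]ccc4c3)nc21` differs from compound 1 at one spot: 4-bromophenyl in place of 2,4-dichlorophenyl on a sulfonyl sulfur. Going by the values given here, no measured pair here shows the effect of changing only the group on the sulfonyl sulfur, so the direction of this step is uncertain. A small step is expected, most likely toward a somewhat higher number, but possibly none beyond the scatter. The estimated step of a 1.5-fold higher number from compound 1 to compound 4 (0.18 log units; within the scatter) is therefore modest, and compound 4 is expected to give 1500 nM in this assay, with a range from 600 nM to 4000 nM.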

Compound 4, half-maximal inhibitory concentration: 5000 nM
Compound 4: middle estimate off by 3.3-fold (0.52 log units), on the low side; the whole stated range lies below it.
By their numbers in this assay, from the lowest: compounds 3 and 1 (each within the scatter of the next); then compounds 2 and 4 (each within the scatter of the next).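

In this assay, replacing 2,4-dichlorophenyl with 4-bromophenyl on the sulfonyl sulfur gives a 5.0-fold higher number from compound 1 to compound 4 (0.70 log units; beyond the scatter) in the first single-place step available here. The group on this sulfur therefore matters, as exchanging one halogenated phenyl for another is enough to shift the result. Nothing at hand explains the shift.

One step cannot show whether the change comes from losing the chlorines, gaining the bromine or altering the substitution pattern on the ring. As far as these compounds go, it also remains open how the result would move if this phenyl carried an amine or a carboxylic acid while the rest of compound 1 stayed the same.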